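Carboxy to 2-carboxyethyl on the shared core

The source may report more compounds than this note shows. Statements on the series, on what has been measured and on what is new or still open speak of the compounds shown alone.

Compound 1 `CCCCCCCCc1ccc(OCC(=O)Cn2nnc(-c3ccccc3Cl)n2)cc1`: 28%
Compound 2 `CCCCCCCCc1ccc(OCC(=O)Cn2nnc(-c3cccc(C(=O)OC)c3)n2)cc1`: 19%
Compound 3 `CCCCCCCCc1ccc(OCC(=O)Cn2nnc(C(=O)O)n2)cc1`: 52%

All three values come from an ADME assay on S9 fraction from liver (Rattus norvegicus) for metabolic stability, read by LC-MS, using NADPH, with a stated time of 30 min; on this read-out lower numbers stand for a less stable compound and higher numbers for a more stable compound. Compound 3 has the highest number of the three, with compound 1 nearest and compound 2 furthest. The next compound is compound 4 `CCCCCCCCc1ccc(OCC(=O)Cn2nnc(CCC(=O)O)n2)cc1`, which carries 2-carboxyethyl in place of carboxy on an aromatic carbon.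

Three measured steps sit at this same place on the core. Between the two compounds with a substituted phenyl group the step is a number 9 percentage points lower from compound 1 to compound 2 (within the scatter). Carboxy replacing those groups gives a number 24 percentage points higher from compound 1 to compound 3 (beyond the scatter) and a number 33 percentage points higher from compound 2 to compound 3 (beyond the scatter). None of these steps lengthens a chain, so the size of this change has not been measured. Compound 4 has no phenyl group at this place, unlike compound 1 with 28% and compound 2 with 19%, and it still holds a carboxy within the new group. A value closer to compound 3 with 52% is therefore expected. In this assay the estimated step is a number 6 percentage points lower from compound 3 to compound 4 (within the scatter), so no step beyond the scatter is expected. The estimated value for compound 4 is 46%, with an expected range of 30% to 62%.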

Compound 4, percent of the compound remaining: < 5%
Compound 4 ended at the assay's limit; the forecaster's own chance of this, stated with the estimate: 2%; middle value at least 41 percentage points away from the limit.
By their numbers in this assay, from the lowest: compounds 2 and 1 (each within the scatter of the next); then compound 3. At a limit, below all of these: compound 4.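

In this assay compound 4 stands at < 5%, which is a limit of the assay and not a number: the limit of < 5% in this assay, at which 1 of the 4 values shown sits.

This position is therefore sensitive to a change that adds no ring and leaves the counted hydrogen-bond donors, hydrogen-bond acceptors and net charge as they were, since 2-carboxyethyl in place of carboxy gives a step that is a number at least 47 percentage points lower from compound 3 to compound 4 (beyond the scatter). The same group also lies under both compounds with a substituted phenyl group, with steps that are a number at least 23 percentage points lower from compound 1 to compound 4 (beyond the scatter) and a number at least 14 percentage points lower from compound 2 to compound 4 (beyond the scatter), so a carboxy held within the group at this place does not by itself carry the standing of compound 3 in this series.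

From the compounds shown here alone, whether carboxymethyl, the chain of intermediate length, would stay near compound 3 or fall towards compound 4 remains open, as does the behaviour of a longer chain ending in a carboxylic acid. Also open, going by these compounds, is whether a primary amide or a methyl ester at the end of the 2-carboxyethyl chain would follow compound 4, and which part of the molecule is lost during the incubation.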